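The compounds below may be only part of what the source reports. "The series", "measured", "known", "first", "only" and "open" are said of these compounds alone.

Measured compounds:
Compound 1 `NCc1ccc(C(=O)Nc2ccncc2)cc1-c1cccc(C(=O)OCC2CCCCC2)c1` gives 48 nM in an assay on isolated protein for inhibition of Rho-associated protein kinase 2 (Homo sapiens), read by radiometric assay; on this read-out lower numbers stand for stronger inhibition and higher numbers for weaker inhibition.
Compound 2 `CCOC(=O)c1cccc(-c2cc(C(=O)Nc3ccncc3)ccc2CN)c1` gives < 1 nM in this assay, which is a limit of the assay and not a number.

Compound 2 thus stands at the limit of < 1 nM in this assay, at which 1 of the 2 values shown sits, so its true value is not resolved. Compound 3 `CCCOC(=O)c1cccc(-c2cc(C(=O)Nc3ccncc3)ccc2CN)c1` differs from compound 2 by methyl in place of hydrogen on a saturated chain carbon, two bonds along the chain from an oxygen next to a carbonyl group. For the measured compounds named here, the one measured step touching this part of the molecule is an at least 48-fold lower number from compound 1 to compound 2 (1.68 log units; beyond the scatter), where a much larger group on the same chain was replaced by a smaller one. Compound 3 moves a single carbon in the other direction, from ethyl to propyl, a far smaller change than that step. The expectation is therefore a step of an at least 1.2-fold higher number from compound 2 to compound 3 (0.07 log units; that floor lies within the scatter), that is, nothing beyond the scatter, with compound 3 expected to stay close to the assay limit. The estimate for compound 3 in this assay is 1.2 nM, with a range from 0.3 nM to 5 nM.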

Compound 3, half-maximal inhibitory concentration: 1.4 nM
Compound 3: middle estimate off by 1.2-fold (0.07 log units), on the low side, and the stated range covers the measured number.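

Adding one carbon at this position, from ethyl to propyl, gives an at least 1.4-fold higher number from compound 2 to compound 3 (0.14 log units; that floor lies within the scatter), so in this assay this small change shows no step that can be called real. For the compounds shown here, compound 3 gives the first measured number for a short chain here, whereas compound 2 gives only a limit of the assay, so the true size of this step stays unknown: the limit of < 1 nM in this assay, at which 1 of the 3 values shown sits. The large gap to the cyclohexyl compound also holds for propyl, not just ethyl, with a 34-fold lower number from compound 1 to compound 3 (1.54 log units; beyond the scatter).

From the compounds shown here alone, what stays open is how the number responds to a butyl or longer straight chain at this position, and so how much size is tolerated before reaching the value of compound 1. Going by these compounds, the effect of an amine or a carboxylic acid at the end of this chain also remains open.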